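The source may report more compounds than this note shows. Statements on the series, on what has been measured and on what is new or still open speak of the compounds shown alone.

- compound 1 `COc1cc(C(=O)c2cn(-c3cccc(C)c3)cc2-c2ccccc2F)cc(OC)c1OC`: 190 nM
- compound 2 `COc1cc(C(=O)c2cn(-c3cccc(C)c3)cc2-c2cccc(N)c2)cc(OC)c1OC`: 130 nM

Among the compounds with values here, in a functional assay on MCF7 cells (Homo sapiens) for cytotoxicity, read by MTT assay, with a stated time of 96 h (a higher number here means a weaker inhibitor, a lower number a stronger inhibitor), compound 1 gives 190 nM, and only one other measured compound is available for comparison. That compound lies within the usual scatter of compound 1, so the two cannot be told apart. The next compound, compound 3 `COc1cc(C(=O)c2cn(-c3ccc(N)cc3)cc2-c2ccccc2F)cc(OC)c1OC`, keeps the 2-fluorophenyl group of compound 1 and carries a new group elsewhere: 4-aminophenyl in place of 3-methylphenyl on an aromatic nitrogen. In words, this is 4-aminophenyl in place of 3-methylphenyl on an aromatic nitrogen. Within the data shown here, the only measured step is a 1.5-fold lower number from compound 1 to compound 2 (0.16 log units; within the scatter). It lies within the scatter and was made at an aromatic carbon, so it offers only weak guidance. Among the measured compounds shown here, no measured pair tests a change on the aromatic nitrogen. The expected step, a 1.6-fold lower number from compound 1 to compound 3 (0.20 log units; within the scatter), is therefore none beyond the scatter, though real uncertainty remains. Compound 3 is expected at 120 nM, with an estimated range of 25 nM to 600 nM.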

Compound 3, half-maximal inhibitory concentration: 28 nM
Compound 3: middle estimate off by 4.3-fold (0.63 log units), on the high side, within the range that was stated.
By their numbers in this assay, from the lowest: compound 3; then compounds 2 and 1 (each within the scatter of the next).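

The group on the aromatic nitrogen of the five-membered ring clearly matters in this assay: 4-aminophenyl in place of 3-methylphenyl gives a 6.8-fold lower number from compound 1 to compound 3 (0.83 log units; beyond the scatter) and so lies beyond the scatter. The earlier pair changed a group on an aromatic carbon and could not be told apart, so this is the first change among these compounds to produce a real difference. The two groups have the same number of heavy atoms, so the step does not come with a larger group, but nothing measured here bears on why the number falls.

This swap introduces the amine and also moves the substituent from the 3-position to the 4-position of the phenyl ring, and the compounds shown do not separate these two changes. A 4-methylphenyl or 4-hydroxyphenyl group on the same nitrogen would test whether the 4-position alone or the amine itself goes with the lower number.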